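Benzyl for cyclohexyl on the amide of compound 3

This account rests on a few compounds, and the source may have more. Where it says the series, first, only, none or still open, it means among the compounds named here.

Compound 3 `Nc1sc(-c2ccc(Br)cc2)c(-c2ccc(Cl)cc2)c1C(=O)NC1CCCCC1` carries a bromo and a chloro aryl group on the shared core and a cyclohexyl on the amide-type nitrogen. Among the compounds with values here, in a functional assay on PC-3 cells (Homo sapiens) for cytotoxicity, read by sulforhodamine B assay, with a stated time of 72 h (on this read-out higher numbers stand for weaker inhibition and lower numbers for stronger inhibition), compound 3 gives 28400 nM, the highest of the three numbers so far. Within the data shown here, compound 1 `Nc1sc(-c2ccc(Cl)cc2)c(-c2ccc(Cl)cc2)c1C(=O)NC1CCCCC1` gives 7300 nM in this assay, and the only single-point step, a 3.9-fold higher number from compound 1 to compound 3 (0.59 log units; beyond the scatter), concerns the halogen, not the amide substituent. Among the measured compounds shown here, compound 2 `Nc1sc(-c2ccc(F)cc2)c(-c2ccc(Cl)cc2)c1C(=O)NCc1ccccc1` gives 25800 nM; it differs from compound 3 in two places, so it yields no clean step, and its number and that of compound 3 sit within the scatter of each other.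

The change to compound 4 `Nc1sc(-c2ccc(Br)cc2)c(-c2ccc(Cl)cc2)c1C(=O)NCc1ccccc1` is benzyl in place of cyclohexyl on an amide-type nitrogen. For the measured compounds named here, no measured pair isolates this change: compound 1 and compound 2 differ both here and at the halogen, so their two numbers cannot be split between the two changes. The expectation therefore rests mainly on compound 3 itself, with only a weak hint from the benzyl-bearing compound 2.

Compound 4 is expected to show a 1.1-fold higher number from compound 3 to compound 4 (0.02 log units; within the scatter), a step not beyond the scatter. The estimate for compound 4 in this assay is 30000 nM, with a range from 10000 nM to 90000 nM.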

Compound 4, half-maximal inhibitory concentration: > 50000 nM
Compound 4 was reported as a limit; the forecaster's own chance of this, stated with the estimate: 20%; middle value at least 1.6-fold (0.22 log units) from the limit.
By their numbers in this assay, from the lowest: compound 1; then compounds 2 and 3 (each within the scatter of the next). At a limit, above all of these: compound 4.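

In this assay compound 4 gives > 50000 nM, which is a limit of the assay and not a number: the limit of > 50000 nM in this assay, at which 1 of the 4 values shown sits.

This gives the first clean read at the amide-type nitrogen, an at least 1.7-fold higher number from compound 3 to compound 4 (0.24 log units; that floor lies within the scatter), so benzyl in place of cyclohexyl does not bring the number down with the bromo and chloro aryl groups held constant, although the floor of this step does not show a change beyond the scatter. The halogen gains a second pair with the benzyl amide, an at least 1.9-fold higher number from compound 2 to compound 4 (0.28 log units; that floor lies within the scatter), and its floor also lies within the scatter, so it adds the same direction to a 3.9-fold higher number from compound 1 to compound 3 (0.59 log units; beyond the scatter) without confirming the size of either step for bromo.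

The compounds shown leave open whether the amide-type nitrogen accepts anything that brings the number down with bromo on the aryl group, such as a phenethyl group, a longer alkyl chain or a chain ending in an amine. Also open, on these data alone, is whether the chloro compound with a benzyl amide would follow compound 1 or stay with compound 4, which would show how far the amide and halogen changes depend on each other.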